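The compounds below may be only part of what the source reports. "The series", "measured", "known", "first", "only" and "open" are said of these compounds alone.

Measured compounds:
compound 1, `Cc1ccc(COc2nc3ccccc3s2)cc1`: "not active" (no number reported)
compound 2, `Fc1ccccc1COc1nc2ccccc2s1`: 51.9%
compound 3, `FC(F)(F)c1ccc(COc2nc3ccccc3s2)cc1`: 99.6%

Of the compounds shown here, three sharing one core have been tested in a functional assay on the whole organism with Mus musculus as the target, in the writhing test, at a dose of 100 mg/kg by the intraperitoneal route; a lower number here means less inhibition, a higher number more inhibition at the dose given (going by the name of the read-out). Compound 1 was reported as "not active" (no number reported) without a number. Compound 2 gives 51.9%, and compound 3 gives 99.6%. Of the two numbers, compound 3 is the highest; the number for compound 2 lies well beyond the usual scatter below it, so compound 3 clearly inhibits more under this test, while compound 1 has no number to compare.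

The next compound is compound 4, `Fc1ccc(COc2nc3ccccc3s2)cc1`. It differs from compound 3 in one place: fluoro in place of trifluoromethyl on an aromatic carbon. Among the measured compounds shown here, no two measured compounds differ in a single place, so there is no measured step to lean on. For the measured compounds named here, the only other compound carrying fluoro, compound 2, sits far below compound 3, and the compound with a small group in the same kind of position, compound 1, was reported as "not active" (no number reported) without a number.

On that basis, compound 4 is expected to fall in this assay by a step of a number 44.6 percentage points lower from compound 3 to compound 4 (beyond the scatter), a drop beyond the scatter. Compound 4 is estimated at 55%, within 20% to 90%.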

Compound 4, a percentage reported as inhibition, in the whole organism at one dose (the size of the read-out at that dose, not a potency): 51.9%
The estimate for compound 4 lay 3.1 percentage points above the measured number; measured number inside the range.
By their numbers in this assay, from the lowest: compounds 2 and 4 (each within the scatter of the next); then compound 3.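

In this assay, among the compounds shown here, the change from trifluoromethyl to fluoro on an aromatic carbon, para to a large group, gives the first step that can be read at a single place: a number 47.7 percentage points lower from compound 3 to compound 4 (beyond the scatter). The group at this position therefore matters a great deal to the read-out, although the smaller fluoro does not remove the effect altogether: compound 4 still gives 51.9%, while compound 1, which carries methyl in the same place, was reported as "not active" (no number reported). Compound 2 also carries fluoro and differs from compound 4 only in where that group sits on the ring, yet compound 2 gives 51.9%, within the scatter of compound 4, so these two compounds show no effect of that shift at this single dose.

Nothing available here explains why swapping these groups has so large an effect. As far as these compounds go, how an amine, a carboxylic acid, a methoxy group or a longer chain would behave at this position remains open, as does whether any other group could match the number given by compound 3.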